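A few compounds are considered here, and "the series" means these few. Any claim that something is new, unique, unknown or untested is made for them only; others in the source may bear on it.

Of the compounds shown here, three share one core and have been tested for how well they stop cancer cells from multiplying. In a functional assay on CWR22R cells (Homo sapiens) for antiproliferative activity, read by propidium iodide staining, with a stated time of 96 h (a lower number here means a stronger inhibitor, a higher number a weaker inhibitor), compound 1 (`CC(O)(CSc1cccc(S(F)(F)(F)(F)F)c1)C(=O)Nc1ccc(C#N)c(C(F)(F)F)c1`) gives 20400 nM and compound 2 (`CC(O)(CSc1cc(C(F)(F)F)cc(C(F)(F)F)c1)C(=O)Nc1ccc(S(F)(F)(F)(F)F)cc1`) gives 15800 nM on the same scale. Compound 3 (`CC(O)(CSc1cccc(S(F)(F)(F)(F)F)c1)C(=O)Nc1cccc(S(F)(F)(F)(F)F)c1`) gives 17200 nM here and so stands within the scatter of both others. None of the three can be ranked above another on these numbers.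

Compound 4 (`CC(O)(CSc1cccc(C(F)(F)F)c1)C(=O)Nc1cccc(S(F)(F)(F)(F)F)c1`) has not been measured yet. It differs from compound 3 in one place (a group of 4 heavy atoms (1 carbon, 3 fluorine; no ring) in place of a group of 6 heavy atoms (5 fluorine, 1 sulfur; no ring), on an aromatic carbon): a trifluoromethyl, a group of 4 heavy atoms (1 carbon, 3 fluorine; no ring), sits in place of a group of 6 heavy atoms (5 fluorine, 1 sulfur; no ring), on an aromatic carbon.

Among the measured compounds shown here, no measured pair differs in one place only, so the data show no direct precedent for this swap. Still, the three compounds carry different groups and their values stay within the scatter of one another. In this assay no step beyond the scatter is therefore expected, in either direction. The estimated step is small (a 1.1-fold lower number from compound 3 to compound 4 (0.03 log units; within the scatter)) and would be hard to tell from noise. The estimate for compound 4 is 16000 nM with the expected range running across (8000 nM to 30000 nM).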

Compound 4, half-maximal inhibitory concentration: 12900 nM
Compound 4: middle estimate off by 1.2-fold (0.09 log units), on the high side; low and high end bracket the measured number.
By their numbers in this assay, from the lowest: compounds 4, 2, 3 and 1 (each within the scatter of the next).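

Among the compounds shown here, compound 3 and compound 4 form the first pair here that differs in one place only, so this position can now be read directly. In this assay the trifluoromethyl in place of the group of 6 heavy atoms (5 fluorine, 1 sulfur), on an aromatic carbon meta to a large group, gives a 1.3-fold lower number from compound 3 to compound 4 (0.12 log units; within the scatter) and so moves the reading by no more than repeat measurements would. At this position in this pair, the smaller group of 4 heavy atoms and the larger group of 6 cannot be told apart, and no measurement at hand says why the two read alike.

From the compounds shown here alone, all four compounds carry fluorine-bearing groups on their aromatic rings, so it stays open whether a group of another kind at this position, such as an amine or a carboxylic acid, would shift the number beyond the scatter. This single pair also leaves open whether the same swap would read alike with a different group on the other side of the amide, such as the nitrile-bearing aromatic ring of compound 1.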